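Adding a Fluorine to a Compound at the Assay Limit

This account rests on a few compounds, and the source may have more. Where it says the series, first, only, none or still open, it means among the compounds named here.

Compound 1 `COc1ccc(/C=C2\S/C(=N\c3ccc(C(C)(C)C)cc3)N(C)C2=O)cc1` gives > 100000 nM in a functional assay on MCF7 cells (Homo sapiens) for antiproliferative activity, read by MTT assay, with a stated time of 72 h (a higher number here means a weaker inhibitor, a lower number a stronger inhibitor), which is a limit of the assay rather than a number.
Compound 2 `COc1ccc(/C=C2/CN(C)/C(=N/c3ccc(Cl)cc3)S2)cc1` gives 7600 nM in this assay.
Compound 3 `COc1ccc(/C=C2\S/C(=N\c3ccccc3)N(C)C2=O)cc1` gives > 100000 nM in this assay, again only a limit.

Compound 3 therefore stands at the limit of > 100000 nM in this assay, at which 2 of the 3 values shown sit, with no number of its own. The step that the two limits leave unreadable from compound 1 to compound 3 cannot be read in size. Compound 4 `COc1ccc(/C=C2\S/C(=N\c3ccc(F)cc3)N(C)C2=O)cc1` differs from compound 3 by fluoro in place of hydrogen on an aromatic carbon. Going by the values given here, no measured step bears on this change, so its size is unknown. Compound 4 is expected to give 150000 nM in this assay, between 30000 nM and 800000 nM, because both compounds carrying the same core sit at the limit of > 100000 nM in this assay, at which 2 of the 3 values shown sit. The expected step that the limit leaves unreadable from compound 3 to compound 4 is a formal one only, and a further limit is the most likely outcome.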

Compound 4, half-maximal inhibitory concentration: 66500 nM
Compound 4: the middle estimate sits 2.3-fold (0.35 log units) above what was measured; the measured number falls inside the stated range.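

In this assay, going by these compounds alone, compound 4 is the only one of the three compounds sharing this core to give a number rather than a limit, so this position can carry a group that leaves a readable value. Fluoro gives an at least 1.5-fold lower number from compound 3 to compound 4 (0.17 log units; that floor lies within the scatter), and in place of tert-butyl it gives an at least 1.5-fold lower number from compound 1 to compound 4 (0.17 log units; that floor lies within the scatter). Compound 1 and compound 3 hold only limits, so both steps are floors and their true sizes stay unknown: the limit of > 100000 nM in this assay, at which 2 of the 4 values shown sit.

On these data alone, whether an amine or a carboxylic acid at this position would give a lower number remains open. So does whether a longer chain there would keep a readable value.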